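Lengthening the alkyl chain from compound 2 to compound 3

The compounds below may be only part of what the source reports. "The series", "measured", "known", "first", "only" and "open" are said of these compounds alone.

Compound 1, `C/C(CC(C)C)=N/Nc1nc(-c2cccc([N+](=O)[O-])c2)cs1`: in an assay on isolated protein for inhibition of Amine oxidase [flavin-containing] A (Homo sapiens), read by fluorescence, with a stated time of 20 min (a higher number here means a weaker inhibitor, a lower number a stronger inhibitor), compound 1 gives 4410 nM.
Compound 2, `CCCC/C(C)=N\Nc1nc(-c2cccc([N+](=O)[O-])c2)cs1`: in this assay compound 2 gives 6330 nM.

Going by the values given here, only two compounds have been measured so far, and the single step between them, a 1.4-fold higher number from compound 1 to compound 2 (0.16 log units; within the scatter), is a change in the shape of the saturated chain that does not move the number beyond the scatter. Compound 2 therefore stands with the highest of the two numbers, but its nearest neighbour, compound 1, lies within the scatter of it, so no order between the two can be claimed.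

Compound 3, `CCCCCC/C(C)=N\Nc1nc(-c2cccc([N+](=O)[O-])c2)cs1`, has not yet been measured. It differs from compound 2 by ethyl in place of hydrogen on a saturated chain carbon, four bonds along the chain from a carbon with a double bond to nitrogen. Among the compounds with values here, the only measured step that bears on this change is the chain alteration from compound 1 to compound 2, which was small. On that basis the step in this assay from compound 2 to compound 3 is expected to be a 1.1-fold higher number from compound 2 to compound 3 (0.04 log units; within the scatter), with no change beyond the scatter clearly indicated. For compound 3 the estimated value in this assay is 7000 nM, within a range from 3000 nM to 16000 nM.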

Compound 3, half-maximal inhibitory concentration: 10900 nM
Estimate against measurement, compound 3: 1.6-fold (0.19 log units) below; low and high end bracket the measured number.
By their numbers in this assay, from the lowest: compounds 1, 2 and 3 (each within the scatter of the next, the first and the last beyond it).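

In this assay, ethyl in place of hydrogen on a saturated chain carbon, four bonds along the chain from a carbon with a double bond to nitrogen, gives a 1.7-fold higher number from compound 2 to compound 3 (0.24 log units; within the scatter) and so does not by itself separate compound 3 from compound 2. The wider change of chain gives a 2.5-fold higher number from compound 1 to compound 3 (0.39 log units; beyond the scatter) and is the first step among these compounds to pass the scatter, a modest one that points towards a higher number and so a weaker inhibitor. Nothing measured beyond these numbers accounts for this step.

Going by these compounds alone, whether a longer chain than the one in compound 3 would carry the number further up, or would leave it where it stands, remains open. Also open, as far as these compounds go, is how this assay would read for a chain ending in an amine or a carboxylic acid, or for a short chain such as methyl or ethyl in the same place.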